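This account rests on a few compounds, and the source may have more. Where it says the series, first, only, none or still open, it means among the compounds named here.

Measured compounds: compound 1 `COc1cc(NC(C)CCCNC(=O)NCc2ccncc2)c2ncccc2c1`, "not determined" (no result reported); compound 2 `COc1cc(NC(C)CCCNC(=O)Nc2ccc(Cl)c(C(F)(F)F)c2)c2ncccc2c1`, "not determined" (no result reported); compound 3 `COc1cc(NC(C)CCCNC(=O)NNC(=O)/C=C/c2ccccc2)c2ncccc2c1`, 13900 nM.

In an ADME assay on L6 cells (Rattus norvegicus) for cytotoxicity, read by resazurin assay, with a stated time of 70 h (on this read-out higher numbers stand for weaker inhibition and lower numbers for stronger inhibition), compound 3 gives 13900 nM and is the only one of the three with a number; compound 1 gives "not determined" (no result reported) and compound 2 gives "not determined" (no result reported) there, so compound 3 stands alone and cannot be ranked against anything. Compound 4 `COc1cc(NC(C)CCCNC(=O)NNC(=O)/C=C/c2ccc(C(F)(F)F)cc2)c2ncccc2c1` differs from compound 3 by trifluoromethyl in place of hydrogen on an aromatic carbon. For the measured compounds named here, no step between two measured compounds is known, so the size of this change can only be guessed from the structures. A small move toward stronger inhibition is expected, a 1.7-fold lower number from compound 3 to compound 4 (0.24 log units; within the scatter), and it may well remain within the scatter. Compound 4 is therefore estimated to give 8000 nM, with a range from 3000 nM to 25000 nM.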

Compound 4, half-maximal inhibitory concentration: 28300 nM
Compound 4: middle estimate off by 3.5-fold (0.55 log units), on the low side; the measured number lies above the stated range.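

In this assay, for the compounds shown here, trifluoromethyl in place of hydrogen on the aromatic carbon gives a 2.0-fold higher number from compound 3 to compound 4 (0.31 log units; beyond the scatter), the first step that can be read. The change points toward weaker inhibition of the cells, so a substituent at this place does move the number, though only modestly.

Going by these compounds, whether a single fluorine, a methoxy group or an amine at the same place would shift the number in the same direction remains open. Nothing available explains the rise seen with trifluoromethyl.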